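This account rests on a few compounds, and the source may have more. Where it says the series, first, only, none or still open, it means among the compounds named here.

Compound 1 `CC(C)c1csc(-c2cccc(CNc3ccc4[nH]nc(C(=O)O)c4c3)c2O)n1`: 65 nM
Compound 2 `CC(C)c1csc(-c2cccc(CN(C)c3ccc4[nH]nc(C(=O)O)c4c3)c2)n1`: 710 nM

Both numbers come from an assay on isolated protein for inhibition of 2-Hydroxyacid oxidase 1 (Homo sapiens), with stated times of 30 min and 15 min; on this read-out higher numbers stand for weaker inhibition and lower numbers for stronger inhibition. In this assay compound 2 gives 710 nM, the higher of the two numbers, which stands for the weaker inhibition, while compound 1 gives 65 nM, a gap that lies well beyond the usual scatter. The two compounds differ in two places at once, in the hydroxy group and in the methyl on the linking nitrogen, so their values alone cannot say how much each of these changes contributes.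

Compound 3 `CC(C)c1csc(-c2cccc(CN(C)c3ccc4[nH]nc(C(=O)O)c4c3)c2O)n1` has not yet been measured. It differs from compound 2 in one place only: hydroxy in place of hydrogen on an aromatic carbon. The step of a 4.7-fold lower number from compound 2 to compound 3 (0.68 log units; beyond the scatter) is expected to lower the number by a clear margin, beyond the scatter, because compound 1, which carries the same hydroxy group, gives 65 nM. Compound 3 is therefore expected to give about 150 nM, with a likely range from 50 nM to 500 nM.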

Compound 3, half-maximal inhibitory concentration: 35 nM
Estimate against measurement, compound 3: 4.3-fold (0.63 log units) above; the measured number lies below the stated range.
By their numbers in this assay, from the lowest: compounds 3 and 1 (each within the scatter of the next); then compound 2.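

In this assay, hydroxy in place of hydrogen on the aromatic carbon ortho to the 4-isopropyl-1,3-thiazol-2-yl group gives a 20-fold lower number from compound 2 to compound 3 (1.31 log units; beyond the scatter), so this single change has a large effect when the linking nitrogen carries a methyl. Methyl in place of hydrogen on that nitrogen, with the hydroxy group present, gives a 1.9-fold lower number from compound 1 to compound 3 (0.27 log units; within the scatter), and this step lies within the scatter, so it shows no clear change in either direction. The two changes that were tangled together in the first pair can now be read apart, and only the hydroxy step lies beyond the scatter; nothing measured here says why the hydroxy group has so large an effect.

Going by these compounds, it remains open whether a methoxy group, a fluorine or an amine at the same carbon would also lower the number, which would show whether a hydroxy group in particular is needed. The methyl step is also known only with the hydroxy group present, so its size without that group, and the outcome with a longer chain such as ethyl on the nitrogen, cannot be told from these compounds.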